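The source may report more compounds than this note shows. Statements on the series, on what has been measured and on what is new or still open speak of the compounds shown alone.

Measured in an in vitro ADME assay on microsomes from liver (Homo sapiens) for pharmacokinetics; a lower number here means slower removal, a higher number faster removal of the compound:
- compound 1 `CC(=O)N[C@@H](CCN1C[C@@H]2CN(C(=O)c3cccc(F)c3)C[C@@H]2C1)c1cccc(F)c1`: 213 mL.min-1.g-1
- compound 2 `O=C(N[C@@H](CCN1C[C@@H]2CN(C(=O)c3cccc(F)c3)C[C@@H]2C1)c1cccc(F)c1)C1CCOC1`: 331 mL.min-1.g-1
- compound 3 `O=C(N[C@@H](CCN1C[C@@H]2CN(C(=O)c3cnccn3)C[C@@H]2C1)c1cccc(F)c1)C1CCCC1`: 909 mL.min-1.g-1

Compound 2, at 331 mL.min-1.g-1, lies within the scatter of compound 1, while compound 3 stands clearly higher. Compound 4 `O=C(N[C@@H](CCN1C[C@@H]2CN(C(=O)c3ccc(C(F)(F)F)nn3)C[C@@H]2C1)c1cccc(F)c1)C1CCOC1` keeps compound 2 except for one group: 6-(trifluoromethyl)pyridazin-3-yl in place of 3-fluorophenyl on a carbonyl carbon. For the measured compounds named here, the only measured step, a 1.6-fold higher number from compound 1 to compound 2 (0.19 log units; within the scatter), changes a different carbonyl carbon, so it says little about this exchange. Compound 3 has another ring on the changed carbonyl carbon, but it also differs elsewhere, so it offers no clean comparison. With no direct evidence, no direction can be favoured. The estimated change is a 1.1-fold lower number from compound 2 to compound 4 (0.04 log units; within the scatter), which is expected to stay within the scatter. For compound 4 the expected value is 300 mL.min-1.g-1, with an estimated range of 120 mL.min-1.g-1 to 700 mL.min-1.g-1.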

Compound 4, intrinsic clearance in microsomes: 263 mL.min-1.g-1
Compound 4: the middle estimate sits 1.1-fold (0.06 log units) above what was measured; the measured number falls inside the stated range.
By their numbers in this assay, from the lowest: compounds 1, 4 and 2 (each within the scatter of the next); then compound 3.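

In this assay, exchanging 3-fluorophenyl for 6-(trifluoromethyl)pyridazin-3-yl on this carbonyl carbon gives a 1.3-fold lower number from compound 2 to compound 4 (0.10 log units; within the scatter). For the compounds shown here, this position therefore accepts a larger aromatic ring that carries two nitrogens and a trifluoromethyl group, and the number stays within the scatter of the one for compound 2. Nothing available explains this result. From the compounds shown here alone, the ring and the trifluoromethyl group were exchanged together, so their separate contributions remain unknown. Going by these compounds, it also remains open how a pyridazin-3-yl without trifluoromethyl, or a phenyl bearing an amine, would behave at this position.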